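Trifluoromethoxy for trifluoromethyl on a weak inhibitor

This account rests on a few compounds, and the source may have more. Where it says the series, first, only, none or still open, it means among the compounds named here.

In a functional assay on VCaP cells (Homo sapiens) for antiproliferative activity, read by propidium iodide staining, with a stated time of 96 h (a higher number here means a weaker inhibitor, a lower number a stronger inhibitor), compound 1 `CC(O)(CSc1ccc(OC(F)(F)F)cc1)C(=O)Nc1ccc(S(F)(F)(F)(F)F)cc1` gives 16000 nM, and compound 2 `CC(O)(CS(=O)(=O)c1cccc(C(F)(F)F)c1)C(=O)Nc1cccc(S(F)(F)(F)(F)F)c1` gives 35500 nM. Compound 2 thus has the higher of the two numbers, making it the weaker inhibitor by a gap beyond the usual scatter. Compound 3 `CC(O)(CS(=O)(=O)c1cccc(OC(F)(F)F)c1)C(=O)Nc1cccc(S(F)(F)(F)(F)F)c1` has trifluoromethoxy in place of trifluoromethyl on an aromatic carbon. Among the compounds with values here, no measured pair shows what this swap does, so only a small gain in potency, within the scatter, is expected. The estimated change is a 1.3-fold lower number from compound 2 to compound 3 (0.10 log units; within the scatter). The expected value for compound 3 is 28000 nM, with a range of 12000 nM to 60000 nM.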

Compound 3, half-maximal inhibitory concentration: 20200 nM
Compound 3: the middle estimate sits 1.4-fold (0.14 log units) above what was measured, and the stated range covers the measured number.
By their numbers in this assay, from the lowest: compounds 1, 3 and 2 (each within the scatter of the next, the first and the last beyond it).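

Within the data shown here, this gives the first direct reading of the change: in this assay, going from 3-(trifluoromethyl)phenyl to 3-(trifluoromethoxy)phenyl gives a 1.8-fold lower number from compound 2 to compound 3 (0.24 log units; within the scatter), so the added oxygen at this position leaves the number within the scatter. Nothing measured here gives a reason for this outcome. On these data alone, whether a chlorine atom or an amine at this position would move the number beyond the scatter remains open. As far as these compounds go, it is also open whether the same swap would give a similar step on the shared core with a thioether in place of the sulfone.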